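Swapping a Thiazole for a Methylthiophene

The source may report more compounds than this note shows. Statements on the series, on what has been measured and on what is new or still open speak of the compounds shown alone.

Within the data shown here, compound 3 `c1ccc(-c2nccs2)c(OCC2=NCCN2)c1` is the only compound here with a number in a functional assay for activation of Alpha-1B adrenergic receptor (Homo sapiens), read by calcium flux; a lower number here means that less compound is needed, a higher number that more compound is needed for the effect: compound 3 gives 20 nM. Compound 1 `c1cnc(-c2ccccc2OCC2=NCCN2)nc1` reaches only a limit of the assay, < 100000 nM. Compound 2 `c1ccc(-c2ccncn2)c(OCC2=NCCN2)c1` likewise stops at a limit, < 100000 nM. Among the measured compounds shown here, because two of the three values sit at the limit of < 100000 nM in this assay, at which 2 of the 3 values shown sit, the steps a step that the two limits leave unreadable from compound 1 to compound 2, a step that the limit leaves unreadable from compound 1 to compound 3 and a step that the limit leaves unreadable from compound 2 to compound 3 cannot be read, so no measured step shows how far an aromatic swap shifts this assay. Compound 4 `Cc1ccc(-c2ccccc2OCC2=NCCN2)s1` differs from compound 3 only by 5-methylthiophen-2-yl in place of 1,3-thiazol-2-yl on an aromatic carbon. With no readable step to lean on, the change is expected to stay within the usual scatter, which means a step of a 1.3-fold higher number from compound 3 to compound 4 (0.10 log units; within the scatter) is estimated. Compound 4 is therefore estimated at 25 nM, with a range from 6 nM to 120 nM.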

Compound 4, half-maximal effective concentration: < 100000 nM
Compound 4: a limit, no number; the forecaster's own chance of this, stated with the estimate: 5%; the middle value lies beyond the limit too.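

Compound 4 also stops at a limit, so no step linking it to compound 1, compound 2 or compound 3 can be read: the limit of < 100000 nM in this assay, at which 3 of the 4 values shown sit.

As far as these compounds go, how far any of these aromatic swaps shifts this assay remains open.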